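Series notes: cyclopropyl in place of methoxy on compound 3

The source may report more compounds than this note shows. Statements on the series, on what has been measured and on what is new or still open speak of the compounds shown alone.

Compound 1 `CNc1nc(NC2(C#N)CCCCC2)nc(-n2cnc(C)n2)n1` in an in vitro assay on Sf21 cells for inhibition of high affinity 3',5'-cyclic-AMP phosphodiesterase 7A (Homo sapiens) (on this read-out lower numbers stand for stronger inhibition and higher numbers for weaker inhibition), gives > 5000 nM, which is a limit of the assay and not a number.
Compound 2 `CNc1nc(NC)nc(NC2(C#N)CCCCC2)n1` in this assay gives > 1000 nM, again a limit of the assay.
Compound 3 `CNc1nc(NC2(C#N)CCCCC2)nc(OC)n1` in this assay gives 521 nM.

Among the compounds with values here, compound 3 therefore holds the only actual number among the three values shown; the other two are limits. Both measured steps that lead into compound 3 bring in the methoxy: an at least 9.5-fold lower number from compound 1 to compound 3 (0.98 log units; beyond the scatter) and an at least 1.9-fold lower number from compound 2 to compound 3 (0.28 log units; that floor lies within the scatter). The remaining step, a step that the two limits leave unreadable from compound 1 to compound 2, cannot be read because of the limit of > 1000 nM in this assay, at which 1 of the 3 values shown sits, and (the limit of > 5000 nM in this assay, at which 1 of the 3 values shown sits).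

Compound 4 `CNc1nc(NC2(C#N)CCCCC2)nc(C2CC2)n1` differs from compound 3 in one place: cyclopropyl in place of methoxy on an aromatic carbon. Within the data shown here, no measured step exchanges the methoxy for any other group, so the two steps that reach compound 3 give no direct reading of this change. With nothing to anchor a direction, the step is expected to stay within the scatter, a 1.2-fold higher number from compound 3 to compound 4 (0.06 log units; within the scatter), and compound 4 is estimated at 600 nM in this assay, with a range from 150 nM to 2500 nM.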

Compound 4, half-maximal inhibitory concentration: 539 nM
For compound 4 the middle estimate is 1.1-fold (0.05 log units) above the measured one; measured number inside the range.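

At this position, on the aromatic carbon between two ring nitrogen atoms, the methoxy now has a direct exchange in this assay, and the all-carbon cyclopropyl reads the same: a 1.0-fold higher number from compound 3 to compound 4 (0.01 log units; within the scatter). Cyclopropyl also gives an at least 9.2-fold lower number from compound 1 to compound 4 (0.96 log units; beyond the scatter), which lies beyond the scatter, while an at least 1.8-fold lower number from compound 2 to compound 4 (0.26 log units; that floor lies within the scatter) has a floor within it. Both are floors only, set by limits of the assay and not by numbers: the limit of > 1000 nM in this assay, at which 1 of the 4 values shown sits, and (the limit of > 5000 nM in this assay, at which 1 of the 4 values shown sits).

Going by these compounds, what an ethyl chain, a dimethylamino group or a carboxylic acid would give at this position stays open. Also open, on these data alone, is whether methoxy and cyclopropyl would still read alike with a different group in place of the methylamino group.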